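Phenyl for propyl on the chain of compound 2

The compounds below may be only part of what the source reports. "The series", "measured", "known", "first", "only" and "open" are said of these compounds alone.

Compound 2 `CCCC[C@H](CCn1cncn1)c1ccc(Cl)cc1Cl` is tested in an ADME assay on RD cells (Homo sapiens) for cytotoxicity, read by MTT assay, with a stated time of 3 days (a higher number here means that more compound is tolerated, a lower number that less compound is tolerated), where compound 2 gives 10.1 ug/mL. Among the three compounds measured so far it holds the second highest number. Compound 1 `CCC[C@@H](CCn1cncn1)c1ccc(C)cc1` gives 74.1 ug/mL in this assay, the highest of the three, and compound 3 `CCCC[C@@H](CCn1cncn1)c1ccc(Cl)cc1Cl` gives 1.9 ug/mL, the lowest. Going by the values given here, the only step between directly comparable compounds is a 5.3-fold lower number from compound 2 to compound 3 (0.73 log units; beyond the scatter), and it rests on (the fact that compounds 2 and 3 differ only in the configuration as drawn).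

Compound 4 `Clc1ccc([C@@H](CCn2cncn2)Cc2ccccc2)c(Cl)c1` differs from compound 2 in one place: phenyl in place of propyl on a saturated chain carbon, two bonds along the chain from an aromatic carbon. Among the compounds with values here, none of the measured steps bears directly on this change, since the single step available, from compound 2 to compound 3, concerns configuration alone and leaves every atom and bond untouched. The spread across the three measured values shows that alterations to this scaffold can move the number well beyond the scatter, but gives no direction for a larger side group on the saturated chain carbon. Compound 4 is therefore expected to lie near compound 2, with a step of a 1.4-fold lower number from compound 2 to compound 4 (0.16 log units; within the scatter) that need not exceed the scatter. On this basis compound 4 is estimated at 7 ug/mL, within a range from 2 ug/mL to 25 ug/mL.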

Compound 4, half-maximal cytotoxic concentration: 6.5 ug/mL
Compound 4: the middle estimate sits 1.1-fold (0.03 log units) above what was measured; measured number inside the range.
By their numbers in this assay, from the lowest: compound 3; then compounds 4 and 2 (each within the scatter of the next); then compound 1.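

In this assay the exchange of propyl for phenyl, which replaces an open chain of 3 heavy atoms with a six-membered aromatic ring of 6 heavy atoms, gives a 1.6-fold lower number from compound 2 to compound 4 (0.19 log units; within the scatter) and so cannot be told apart from repeat measurement. Going by these compounds alone, this is the first sign that the place on a saturated chain carbon, two bonds along the chain from an aromatic carbon, tolerates a larger ring-bearing group without a clear shift in the number, whereas the other step on hand, a 5.3-fold lower number from compound 2 to compound 3 (0.73 log units; beyond the scatter) and thus a change of configuration alone, does lie outside that scatter. Nothing in the information available accounts for the outcome of this exchange.

The compounds shown leave open whether the same flat result would hold for cyclohexyl, which would separate ring size from aromatic character, or for a longer chain, or for a chain ending in an amine or a carboxylic acid at this place. They also leave open whether the opposite configuration of compound 4 would open a gap of the kind seen with the butyl-bearing pair.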